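This account rests on a few compounds, and the source may have more. Where it says the series, first, only, none or still open, it means among the compounds named here.

Measured so far in a functional assay, read by MTT assay, with a stated time of 4 h; on this read-out lower numbers stand for stronger inhibition and higher numbers for weaker inhibition:
compound 1, `O=C(c1ccccc1)c1cc(O)c(O)cc1Br`, gives 84000 nM
compound 2, `Oc1cc(Br)c(Cc2ccccc2)cc1O`, gives 164000 nM
compound 3, `O=C(c1ccccc1)c1cc(O)c(O)c(Br)c1Br`, gives 87700 nM

Compound 4, `Oc1cc(Cc2ccccc2)c(Br)c(Br)c1O`, has not yet been measured in this assay. Compound 3 comes from compound 1 by bromo in place of hydrogen on an aromatic carbon, and that step was a 1.0-fold higher number from compound 1 to compound 3 (0.02 log units; within the scatter). Compound 4 comes from compound 2 by bromo in place of hydrogen on an aromatic carbon. The surroundings are not word for word the same: in compound 1 the new bromo is meta to a group of 8 heavy atoms, in compound 2 it is meta to a group of 7 heavy atoms, so this is the same kind of change rather than the same one. The difference between the two cores of compound 1 and compound 2 is not broken down here. Because the earlier step of a 1.0-fold higher number from compound 1 to compound 3 (0.02 log units; within the scatter) stayed within the scatter, the step for compound 4 is expected to be a 1.0-fold higher number from compound 2 to compound 4 (0.02 log units; within the scatter). Compound 4 is therefore estimated at 170000 nM in this assay, with a likely range from 80000 nM to 360000 nM.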

Compound 4, half-maximal inhibitory concentration: 88000 nM
Estimate against measurement, compound 4: 1.9-fold (0.29 log units) above; low and high end bracket the measured number.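

In this assay, adding the second bromo to the core of compound 2 gives a 1.9-fold lower number from compound 2 to compound 4 (0.27 log units; within the scatter), and the step matches the one seen on the core of compound 1: the same change on two cores in this assay, a 1.0-fold higher number (0.02 log units; within the scatter) from compound 1 to compound 3 and a 1.9-fold lower number (0.27 log units; within the scatter) from compound 2 to compound 4, 1.9-fold (0.29 log units) apart, within the scatter of two such steps On these two pairs, bromo in place of hydrogen on an aromatic carbon carries from one core to the other with no difference that stands out from the scatter. With both steps also within the scatter, this does not show that the added bromo changes the read-out on either core, nor that the match would hold on any further core.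

The compounds shown leave open how a different group on the same aromatic carbon, such as an amine, a methyl group or a carboxylic acid, would read. They also leave open whether any such group would give a step beyond the scatter.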